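Morpholine in place of thiomorpholine in a thiosemicarbazide pair

The source may hold more compounds than are shown below. What is called first, only, known or untested is meant among the compounds shown, and "the series" means these compounds.

Compound 1 `N/C(=N\NC(=S)N1CCOCC1)c1ccccn1`: 29.2%
Compound 2 `N/C(=N\NC(=S)N1CCSCC1)c1ccc(F)cn1`: 48.7%

In a functional assay on A-431 cells (Homo sapiens) for cytotoxicity, read by MTT assay, with a stated time of 72 h, tested at 1 uM (a higher number here means more inhibition of growth at the concentration tested, a lower number less inhibition of growth), compound 2 gives the higher of the two numbers; compound 1 stands lower by a margin beyond the scatter. Among the measured compounds shown here, the two differ in two places at once, so no single step between them can be drawn. Compound 3 `N/C(=N\NC(=S)N1CCOCC1)c1ccc(F)cn1` keeps the rest of compound 2 and carries morpholin-4-yl in place of thiomorpholin-4-yl on a thiocarbonyl carbon. For the measured compounds named here, with no measured step for this change alone, a modest drop from compound 2 is expected, one that may not clear the scatter. The expected step is a number 10.7 percentage points lower from compound 2 to compound 3 (beyond the scatter). Compound 3 is estimated at 38%, range 22% to 55%.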

Compound 3, percent growth inhibition at one concentration: 31.8%
For compound 3 the middle estimate is 6.2 percentage points above the measured one; measured number inside the range.
By their numbers in this assay, from the lowest: compounds 1 and 3 (each within the scatter of the next); then compound 2.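

In this assay, the morpholin-4-yl swap on the thiocarbonyl carbon now reads as a single change, giving a number 16.9 percentage points lower from compound 2 to compound 3 (beyond the scatter) with the fluoro kept, so thiomorpholin-4-yl is favoured at this position in this pair. Fluoro in place of hydrogen on an aromatic carbon gives a number 2.6 percentage points higher from compound 1 to compound 3 (within the scatter) with morpholin-4-yl held, so this pair shows no separable fluoro effect. Nothing available explains the step at the thiocarbonyl carbon.

Open, going by these compounds, is whether piperidin-1-yl or 4-methylpiperazin-1-yl at that carbon would track compound 2 or compound 3. Also open, on these data alone, is how fluoro behaves alongside thiomorpholin-4-yl.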